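The source may report more compounds than this note shows. Statements on the series, on what has been measured and on what is new or still open speak of the compounds shown alone.

Three compounds share one core and were measured in a functional assay, with a stated time of 20 min, tested at 50 uM; on this read-out higher numbers stand for a stronger effect at the one concentration tested and lower numbers for a weaker effect. Compound 1 `COc1cc(/C=C/C(=O)C2=C(/C=C/c3ccc(O)c(OC)c3)NC(=O)NC2c2ccccc2)ccc1O` gives 50.2% in this assay. Compound 2 `COc1cc(/C=C/C(=O)C2=C(/C=C/c3ccc(O)c(OC)c3)NC(=O)NC2c2ccc(N(C)C)cc2)ccc1O` gives 89.2% in this assay, and compound 3 `COc1cc(/C=C/C(=O)C2=C(/C=C/c3ccc(O)c(OC)c3)NC(=O)NC2c2c(Cl)cccc2Cl)ccc1O` gives 44.2% in this assay. On these numbers compound 3 stands lowest of the three, within the scatter of compound 1 through a number 6 percentage points lower from compound 1 to compound 3 (within the scatter), and clearly below compound 2 through a number 45 percentage points lower from compound 2 to compound 3 (beyond the scatter). Compound 4 `COc1cc(/C=C/C(=O)C2=C(/C=C/c3ccc(O)c(OC)c3)NC(=O)NC2c2ccccc2Cl)ccc1O` differs from compound 3 by hydrogen in place of chloro on an aromatic carbon. The step of a number 39 percentage points higher from compound 1 to compound 2 (beyond the scatter) concerns a different group and does not bear on this. Compound 4 is expected to shift only within the scatter, a number 2.8 percentage points higher from compound 3 to compound 4 (within the scatter), because the related step of a number 6 percentage points lower from compound 1 to compound 3 (within the scatter) was itself within the scatter. Compound 4 is estimated at 47%, in the range 35% to 60%.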

Compound 4, a percentage reported as activity, at one concentration (the size of the read-out at that concentration, not a potency): 56%
The estimate for compound 4 lay 9 percentage points below the measured number, and the stated range covers the measured number.
By their numbers in this assay, from the lowest: compounds 3, 1 and 4 (each within the scatter of the next, the first and the last beyond it); then compound 2.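

Among these compounds, removing one chloro, from 2,6-dichlorophenyl to 2-chlorophenyl, gives a number 11.8 percentage points higher from compound 3 to compound 4 (beyond the scatter) in this assay, the first step among the chlorinated compounds to pass the scatter. Yet a single chloro in place of hydrogen gives only a number 5.8 percentage points higher from compound 1 to compound 4 (within the scatter), and the chloro series stays well apart from the dimethylamino compound, with a number 33.2 percentage points lower from compound 2 to compound 4 (beyond the scatter). Nothing shown here gives a reason for these steps.

On these data alone, it remains open whether a methoxy group or a carboxylic acid on this phenyl ring would read like the dimethylamino group or like chloro. A smaller amine could also test whether the high number of compound 2 extends beyond dimethylamino.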